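The compounds below may be only part of what the source reports. "The series", "measured", "known", "first", "only" and "open" are said of these compounds alone.

Compound 1 `Nc1nn(C(=O)Nc2ccc(Cc3ccccc3)cc2)c2ccccc12` carries hydrogen at the aromatic carbon under study. In a functional assay on ACHN cells (Homo sapiens) for antiproliferative activity, read by sulforhodamine B assay, with a stated time of 48 h (on this read-out higher numbers stand for lower toxicity in this test and lower numbers for higher toxicity in this test), compound 1 gives only a limit of the assay, > 100000 nM. Compound 2 `Nc1nn(C(=O)Nc2ccc(Cc3ccccc3)cc2)c2ccc(Cl)cc12` differs by chloro in place of hydrogen on an aromatic carbon. In this assay compound 2 likewise gives only a limit of the assay, > 100000 nM. The step that the two limits leave unreadable from compound 1 to compound 2 therefore cannot be sized, since both values sit at the limit of > 100000 nM in this assay, at which 2 of the 2 values shown sit. Compound 2 thus stands at the ceiling of the measured range, with nothing to rank it against compound 1. Compound 3 `Nc1ccc2c(c1)c(N)nn2C(=O)Nc1ccc(Cc2ccccc2)cc1` has not yet been measured; it differs from compound 2 by amino in place of chloro on an aromatic carbon. For the measured compounds named here, the one measured step at this aromatic carbon is unreadable, so the data give no direction for the change. The step is expected to be a step that the limit leaves unreadable from compound 2 to compound 3, within the scatter. Compound 3 is estimated in this assay at 150000 nM, with a range from 50000 nM to 500000 nM.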

Compound 3, concentration lethal to 50% of the cells: 39600 nM
The estimate for compound 3 lay 3.8-fold (0.58 log units) above the measured number; measured number outside the range, below it.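

At this aromatic carbon, amino is the only group shown that brings a readable value into this assay: amino in place of chloro gives an at least 2.5-fold lower number from compound 2 to compound 3 (0.40 log units; beyond the scatter), and amino in place of hydrogen gives an at least 2.5-fold lower number from compound 1 to compound 3 (0.40 log units; beyond the scatter). Lower numbers here stand for higher toxicity in this test, so this position does respond to a change, which the unreadable step for chloro in place of hydrogen could not show. Both new steps are only minimum sizes, because compound 1 and compound 2 each give a limit of the assay rather than a number: the limit of > 100000 nM in this assay, at which 2 of the 3 values shown sit.

The compounds shown leave open whether a methylamino or acetamido group, or a hydroxyl, at this carbon would behave as amino does. On these data alone, the step between compound 1 and compound 2 also remains unreadable, so any difference between hydrogen and chloro stays unknown.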